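The source may report more compounds than this note shows. Statements on the series, on what has been measured and on what is new or still open speak of the compounds shown alone.

Working notes on a small series sharing one core, read in an ADME assay on Raji cells (Homo sapiens) for cytotoxicity, with a stated time of 72 h; on this read-out higher numbers stand for an effect only at larger amounts of compound and lower numbers for an effect already at smaller amounts. Among the compounds with values here, compound 1 `COC(=O)c1cccc(NC(=O)Nc2cc(C)nc3ccccc23)c1` gives 26000 nM, the only true number in the set. Compound 2 `Cc1cc(NC(=O)Nc2cccc(N(C)C)c2)c2ccccc2n1` returns only a limit, > 25000 nM. Compound 3 `COc1cccc(NC(=O)Nc2cc(C)nc3ccccc23)c1` also returns only a limit, > 25000 nM. Compound 3 therefore has no exact position and stands with compound 2 at the limit of > 25000 nM in this assay, at which 2 of the 3 values shown sit.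

Compound 4 `Cc1cc(NC(=O)Nc2cccc(OC(F)(F)F)c2)c2ccccc2n1` departs from compound 3 at one place: trifluoromethyl in place of methyl on an oxygen on an aromatic ring. This is trifluoromethyl in place of methyl on an oxygen on an aromatic ring, or methoxy to trifluoromethoxy when cut one bond further out.

The nearest measured changes are a step that the limit leaves unreadable from compound 1 to compound 3, a step that the two limits leave unreadable from compound 2 to compound 3 and a step that the limit leaves unreadable from compound 1 to compound 2. Each exchanges a group on an aromatic carbon, none has a readable size, and none includes trifluoromethoxy. They therefore provide no size or direction to carry over. No step beyond the scatter is expected in this assay, and a further limit is a likely outcome.

The expected step is a number no higher from compound 3 to compound 4 (the limit leaves the size open). For compound 4, the estimated value is 25000 nM, with an expected range of 12000 nM to 50000 nM.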

Compound 4, half-maximal effective concentration: 9000 nM
The estimate for compound 4 lay 2.8-fold (0.44 log units) above the measured number; measured number below the stated range.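

Trifluoromethyl in place of methyl on an oxygen on an aromatic ring gives an at least 2.7-fold lower number from compound 3 to compound 4 (0.44 log units; beyond the scatter) in this assay, so this group change produces the first readable step to or from compound 3. Within the data shown here, compound 4 also separates from the other two members, with an at least 2.7-fold lower number from compound 2 to compound 4 (0.44 log units; beyond the scatter) and a 2.9-fold lower number from compound 1 to compound 4 (0.46 log units; beyond the scatter), which makes it the only compound in the set whose steps to all the others are printed as beyond the scatter. The steps among the three earlier compounds still cannot be read, and compound 2 and compound 3 each remain at a limit rather than a number: the limit of > 25000 nM in this assay, at which 2 of the 4 values shown sit.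

Whether the lower number follows from the trifluoromethoxy group in particular stays open, as a primary amine, a carboxylic acid or a longer alkoxy chain such as ethoxy on the same aromatic carbon does not appear among the compounds shown. Among these compounds, with only one fluorine-bearing group in the set, it also remains open whether trifluoromethyl on an oxygen would give a step of similar size on a different core.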